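Adding a Methoxy Group to Compound 2

The source may report more compounds than this note shows. Statements on the series, on what has been measured and on what is new or still open speak of the compounds shown alone.

Compound 1 `CCOc1cc(OC)cc(OC)c1C(=O)/C=C/c1cccc(OC)c1`: 34000 nM
Compound 2 `COc1cccc(/C=C/C(=O)c2ccc(OC)cc2O)c1`: 29700 nM

In an ADME assay on RAW264.7 cells (Mus musculus) for cytotoxicity, read by MTT assay, with a stated time of 24 h (on this read-out lower numbers stand for stronger inhibition and higher numbers for weaker inhibition), compound 2 gives 29700 nM and compound 1 gives 34000 nM, so the two lie within the usual scatter of each other. Compound 3 `COc1cccc(/C=C/C(=O)c2c(O)cc(OC)cc2OC)c1` has methoxy in place of hydrogen on an aromatic carbon of compound 2: methoxy in place of hydrogen on an aromatic carbon. Within the data shown here, no measured pair shows this change directly. Among the measured compounds shown here, the only guide is compound 1 at 34000 nM, which also holds two methoxy groups on the ring that changes. No shift beyond the scatter is expected in this assay, in either direction. The expected step is a 1.0-fold higher number from compound 2 to compound 3 (0.00 log units; within the scatter). For compound 3 the estimate is 30000 nM, with an expected range from 14000 nM to 62000 nM.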

Compound 3, half-maximal inhibitory concentration: 34000 nM
Beside the measured number, compound 3's estimate is 1.1-fold (0.05 log units) below it; low and high end bracket the measured number.
By their numbers in this assay, from the lowest: compounds 2, 1 and 3 (each within the scatter of the next).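

In this assay, among these compounds, adding methoxy at this position, ortho to a large group, gives a 1.1-fold higher number from compound 2 to compound 3 (0.06 log units; within the scatter) and so provides the first direct reading of this change: the added group moves the number no further than the usual scatter. Putting hydrogen in place of ethyl on an oxygen on the ring gives no change at the digits printed from compound 1 to compound 3 (within the scatter) and also stays within the scatter. Nothing available explains either result. Still open, going by these compounds, is whether an amine or a carboxylic acid on this aromatic carbon would shift the number beyond the scatter.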